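The source may report more compounds than this note shows. Statements on the series, on what has been measured and on what is new or still open speak of the compounds shown alone.

Within the data shown here, compound 2, `c1cn2cc(-c3ccsc3)nc(-c3ccc4ncn(C5CCCCC5)c4c3)c2n1`, is one of two compounds measured so far in a functional assay on HT-29 cells (Homo sapiens) for inhibition, read by sulforhodamine B assay, with a stated time of 48 h, tested at 10 uM; a lower number here means less inhibition, a higher number more inhibition at the concentration tested (going by the name of the read-out). In this assay compound 2 gives 5.68%. Among the measured compounds shown here, its only measured neighbour is compound 1, `O=Cc1ccc(-c2cn3ccnc3c(-c3ccc4ncn(C5CCCCC5)c4c3)n2)cc1`, which in this assay gives 17.5%. For the measured compounds named here, on these two numbers compound 2 stands lowest, and the single step that joins them, a number 11.8 percentage points lower from compound 1 to compound 2 (beyond the scatter), is the only measured change available.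

Compound 3, `CC(=O)c1ccc(-c2cn3ccnc3c(-c3ccc4ncn(C5CCCCC5)c4c3)n2)cc1`, has not yet been tested. It differs from compound 2 in one place: 4-acetylphenyl in place of thiophen-3-yl on an aromatic carbon.

The step from compound 1 to compound 2 is the one that bears on this change. There, 4-formylphenyl gave way to thiophen-3-yl and the inhibition fell, beyond the scatter. Compound 3 runs that exchange in the opposite direction, restoring a six-membered aromatic ring of carbon only that carries a carbonyl, and 4-acetylphenyl is close in make-up to 4-formylphenyl. A rise of about the same modest size as that step is therefore expected for compound 3, a number 9.3 percentage points higher from compound 2 to compound 3 (within the scatter). Compound 3 is accordingly estimated to give 15% in this assay, within a range from 4% to 28%.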

Compound 3, a percentage reported as inhibition, at one concentration (the size of the read-out at that concentration, not a potency): 9.2%
Beside the measured number, compound 3's estimate is 5.8 percentage points above it, within the range that was stated.
By their numbers in this assay, from the lowest: compounds 2, 3 and 1 (each within the scatter of the next, the first and the last beyond it).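

Moving from thiophen-3-yl to 4-acetylphenyl at this position in this assay gives a number 3.5 percentage points higher from compound 2 to compound 3 (within the scatter) and so cannot be told apart from no change, which means that a six-membered aromatic ring of carbon only carrying a carbonyl does not clearly bring back the level of compound 1. Methyl in place of hydrogen on the carbonyl carbon gives a number 8.3 percentage points lower from compound 1 to compound 3 (within the scatter) and is equally unresolved, so compound 3 lies within the scatter of both its neighbours, and the gap between compound 1 and compound 2 remains the only one beyond the scatter. With this compound in between, that gap can no longer be read as a clean contrast between the two ring types, and nothing measured here offers an explanation for these numbers.

The compounds shown leave open how the inhibition would respond if an amine or a carboxylic acid replaced the carbonyl group on the phenyl ring. They also leave open whether a longer chain than methyl on the carbonyl carbon would separate such a compound from compound 1 by more than the scatter.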